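This account rests on a few compounds, and the source may have more. Where it says the series, first, only, none or still open, it means among the compounds named here.

Measured compounds and their numbers:

Compound 1 `C=C(Br)C(=O)Nc1cccc(-c2cn3nc(Cc4ccccc4)sc3n2)c1` gives 3000 nM in a functional assay on L1210 cells (Mus musculus) for inhibition, read by cell counting, with a stated time of 2 days; on this read-out lower numbers stand for stronger inhibition and higher numbers for weaker inhibition.
Compound 2 `C=C(Br)C(=O)Nc1cccc(-c2cn3nc(-c4ccccc4)sc3n2)c1` gives 600 nM in this assay.
Compound 3 `C=C(Br)C(=O)Nc1cccc(-c2cn3nc(-c4cccc(OC)c4)sc3n2)c1` gives 580 nM in this assay.

On these numbers compound 3 and compound 2 cannot be told apart: a 1.0-fold lower number from compound 2 to compound 3 (0.01 log units; within the scatter). Both stand clearly apart from compound 1, the benzyl compound, as a 5.0-fold lower number from compound 1 to compound 2 (0.70 log units; beyond the scatter) and a 5.2-fold lower number from compound 1 to compound 3 (0.71 log units; beyond the scatter) show. The shared core with an aryl group attached thus gives a lower number than the core with a benzyl group, and the methoxy group on that aryl ring made no difference that rises above the scatter.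

Compound 4 `C=C(Br)C(=O)Nc1cccc(-c2cn3nc(-c4ccc(OC)cc4)sc3n2)c1` differs from compound 3 in one respect: 4-methoxyphenyl in place of 3-methoxyphenyl on an aromatic carbon. The same atoms are present, only the methoxy group sits at a different place on the phenyl ring. Going by the values given here, no measured pair compares two placements of a methoxy group, so the only step that bears on this change is the one in which the methoxy group was introduced, a 1.0-fold lower number from compound 2 to compound 3 (0.01 log units; within the scatter), and that step stayed within the scatter. Because a 1.0-fold lower number from compound 2 to compound 3 (0.01 log units; within the scatter) shows the methoxy group to be nearly silent, moving it is expected to matter little, and the expected step is a 1.0-fold higher number from compound 3 to compound 4 (0.01 log units; within the scatter). Compound 4 is therefore estimated at 600 nM, with a range from 250 nM to 1500 nM.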

Compound 4, half-maximal inhibitory concentration: 940 nM
Compound 4: middle estimate off by 1.6-fold (0.19 log units), on the low side; the measured number falls inside the stated range.
By their numbers in this assay, from the lowest: compounds 3, 2 and 4 (each within the scatter of the next); then compound 1.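

Moving the methoxy group on the phenyl ring gives a 1.6-fold higher number from compound 3 to compound 4 (0.21 log units; within the scatter) in this assay, and this is the first direct comparison of two placements at this position, next to the ring sulfur; the step stays within the scatter. Compound 4 also cannot be told apart from the plain phenyl compound, as a 1.6-fold higher number from compound 2 to compound 4 (0.19 log units; within the scatter) shows, so neither methoxy placement shifts the number beyond the scatter, while the gap to the benzyl compound remains in a 3.2-fold lower number from compound 1 to compound 4 (0.50 log units; beyond the scatter), also with the methoxy group at the 4-position of the ring. Nothing available explains these numbers or why the aryl compounds stand apart from the benzyl compound.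

The compounds shown all carry either benzyl or phenyl with at most a methoxy group, so it remains open whether an amine or a carboxylic acid on that phenyl ring would move the number beyond the scatter. On these data alone, it also remains open whether a longer chain between the shared core and the phenyl ring would take the number further from the aryl compounds than benzyl does.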